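Swapping a methylpyrazole for a methyltriazole on a sulfonyl

This account rests on a few compounds, and the source may have more. Where it says the series, first, only, none or still open, it means among the compounds named here.

Compound 1 `Cn1cnnc1S(=O)(=O)N1CCC(CNC(=O)c2ccc(Cl)cc2Cl)(CC2CC2)CC1`: 124 nM
Compound 2 `Cn1cc(S(=O)(=O)N2CC(CNC(=O)c3ccc(Cl)cc3Cl)(CC3CC3)C2)cn1`: 3.62 nM
Compound 3 `Cn1cc(S(=O)(=O)N2CCC(CNC(=O)c3ccc(Cl)cc3Cl)(CC3CC3)CC2)nn1`: 32 nM

The three measured compounds were tested in an assay on JAR cells for inhibition of sodium- and chloride-dependent glycine transporter 1 (Homo sapiens), read by scintillation counting, with a stated time of 3 h; on this read-out lower numbers stand for stronger inhibition and higher numbers for weaker inhibition. Compound 2 stands lowest of the three numbers; its nearest neighbour is compound 3, and compound 1 lies furthest from it, both gaps beyond the scatter. Compound 4 `Cn1ncc(S(=O)(=O)N2CC(CNC(=O)c3ccc(Cl)cc3Cl)(CC3CC3)C2)n1` is built from compound 2 by a single exchange: 2-methyl-2H-1,2,3-triazol-4-yl in place of 1-methyl-1H-pyrazol-4-yl on a sulfonyl sulfur.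

For the measured compounds named here, only one measured step concerns the group on the sulfonyl sulfur, and it is a 3.9-fold lower number from compound 1 to compound 3 (0.59 log units; beyond the scatter). Going by the values given here, that step exchanges one methyltriazole for another on a core shared by compound 1 and compound 3, a core that differs from the one compound 2 and compound 4 share, and neither of its two groups is the methylpyrazole that leaves here. The values of compound 2 and compound 3 differ in two places at once, so they isolate nothing about the five-membered ring alone. Among the compounds with values here, with only that indirect step to lean on, the expected change from compound 2 to compound 4 in this assay is small, and the estimated step is a 1.4-fold higher number from compound 2 to compound 4 (0.14 log units; within the scatter), inside or close to the scatter. Compound 4 is therefore expected to give about 5 nM, in a range from 2 nM to 15 nM.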

Compound 4, half-maximal inhibitory concentration: 132 nM
Compound 4: middle estimate off by 26-fold (1.42 log units), on the low side; the whole stated range lies below it.
By their numbers in this assay, from the lowest: compound 2; then compound 3; then compounds 1 and 4 (each within the scatter of the next).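

In this assay, the group on the sulfonyl sulfur of this core proves highly sensitive to a small structural change: a 36-fold higher number from compound 2 to compound 4 (1.56 log units; beyond the scatter) follows from replacing 1-methyl-1H-pyrazol-4-yl with 2-methyl-2H-1,2,3-triazol-4-yl. The two groups have the same number of heavy atoms and differ in that a nitrogen of the entering ring stands for a carbon of the leaving one, so a single-atom difference in this ring can carry a large step. For the compounds shown here, the only earlier reading at this place, a 3.9-fold lower number from compound 1 to compound 3 (0.59 log units; beyond the scatter), was a modest step between two methyltriazoles on another core, and nothing available accounts for the size of the new step.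

The compounds shown leave open whether 1-methyl-1H-pyrazol-4-yl would keep its advantage on the core of compound 3, and how 1-methyl-1H-1,2,3-triazol-4-yl would behave on the core of compound 2. They also leave open whether a 1-methyl-1H-imidazol-4-yl group or a plain phenyl ring on the sulfonyl sulfur would follow the methylpyrazole or the methyltriazole in this read-out.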